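The source may report more compounds than this note shows. Statements on the series, on what has been measured and on what is new or still open speak of the compounds shown alone.

Compound 1 `O=C(OCCCCO)OCCc1ccc(O)c(O)c1` gives "not determined" (no result reported)
Compound 2 `O=C(OCCCCCCO)OCCc1ccc(O)c(O)c1` gives > 50000 nM
Compound 3 `CCCCOC(=O)OCCc1ccc(O)c(O)c1` gives "not determined" (no result reported)

These three compounds were examined in an ADME assay on MRC5 cells (Homo sapiens) for inhibition, read by MTT assay, with a stated time of 72 h (on this read-out lower numbers stand for stronger inhibition and higher numbers for weaker inhibition), as a measure of their effect on cultured cells. Compound 3 has no single number to its name, so its standing cannot be placed on the scale. For the measured compounds named here, the only other reading with any numerical content is the limit of > 50000 nM in this assay, at which 1 of the 3 values shown sits, and belongs to compound 2, and it is a limit of the assay rather than a measured number.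

Compound 4 `CCCCCCOC(=O)OCCc1ccc(O)c(O)c1` is the next compound to consider, and it differs from compound 3 by ethyl in place of hydrogen on a saturated chain carbon, four bonds along the chain from an oxygen next to a carbonyl group in one place: ethyl in place of hydrogen on a saturated chain carbon, four bonds along the chain from an oxygen next to a carbonyl group. Going by the values given here, no measured pair shows what this change does, so the expectation is for no step beyond the scatter in this assay and no firm direction. The result is expected to lie close to the limit seen for compound 2 and may well be reported only as a limit.

For compound 4 the estimated value is 50000 nM with an expected range from 20000 nM to 100000 nM.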

Compound 4, half-maximal inhibitory concentration: 11200 nM
For compound 4 the middle estimate is 4.5-fold (0.65 log units) above the measured one; the measured number lies below the stated range.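

For the compounds shown here, compound 4 gives the first single number in this assay, and with it the first readable change at the far end of the chain: hydrogen in place of hydroxy on a saturated chain carbon, six bonds along the chain from an oxygen next to a carbonyl group, brings an at least 4.4-fold lower number from compound 2 to compound 4 (0.64 log units; beyond the scatter). In this pair, then, losing the hydroxy goes with stronger inhibition of these cells. The size of that step is only a minimum, since compound 2 stands at a limit of the assay and not at a number: the limit of > 50000 nM in this assay, at which 1 of the 4 values shown sits.

Steps involving compound 1 or compound 3 cannot be read, so what ethyl in place of hydrogen does at its place stays unknown. From the compounds shown here alone, whether a longer chain, or an amine or a carboxylic acid at the chain end, would shift the number further also stays open.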